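Oxan-4-yl in place of methyl on the chain

The compounds below may be only part of what the source reports. "The series", "measured", "known", "first", "only" and "open" are said of these compounds alone.

Among the compounds with values here, in a physicochemical assay for solubility, in phosphate buffer, at pH 7.4 (on this read-out higher numbers stand for higher solubility and lower numbers for lower solubility), compound 1 `CCNC(=O)Nc1nc2cc(-c3cccnc3)c(=O)n(CC)c2s1` gives 94000 nM, the highest of the three numbers so far. Compound 2 `CCNC(=O)Nc1nc2cc(-c3cccnc3)c(=O)n(CC3CC3)c2s1` gives 5000 nM, and compound 3 `CCNC(=O)Nc1nc2cc(-c3cccnc3)c(=O)n(CC3CCCCC3)c2s1` gives 7000 nM. Compound 4 `CCNC(=O)Nc1nc2cc(-c3cccnc3)c(=O)n(CC3CCOCC3)c2s1` is not yet measured. Its difference from compound 1 is oxan-4-yl in place of methyl on a saturated chain carbon bound to an aromatic nitrogen. Two large steps bear on this change: a 19-fold lower number from compound 1 to compound 2 (1.27 log units; beyond the scatter) and a 13-fold lower number from compound 1 to compound 3 (1.13 log units; beyond the scatter). By contrast, a 1.4-fold higher number from compound 2 to compound 3 (0.15 log units; within the scatter) stays within the scatter. Within the data shown here, no measured compound carries oxan-4-yl, so the size remains uncertain. In this assay, a large downward step is expected: a 7.8-fold lower number from compound 1 to compound 4 (0.89 log units; beyond the scatter). Compound 4 is estimated at 12000 nM, with an expected range of 4000 nM to 35000 nM.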

Compound 4, solubility: 25000 nM
The estimate for compound 4 lay 2.1-fold (0.32 log units) below the measured number; the measured number falls inside the stated range.
By their numbers in this assay, from the lowest: compounds 2 and 3 (each within the scatter of the next); then compound 4; then compound 1.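

Oxan-4-yl in place of methyl still lowers the number in this assay, with a 3.8-fold lower number from compound 1 to compound 4 (0.58 log units; beyond the scatter). Oxan-4-yl also separates from both other rings at this saturated chain carbon, with a 3.6-fold higher number from compound 3 to compound 4 (0.55 log units; beyond the scatter) and a 5.0-fold higher number from compound 2 to compound 4 (0.70 log units; beyond the scatter), whereas cyclopropyl and cyclohexyl lay within the scatter of each other. Nothing on hand gives a cause for these differences.

From the compounds shown here alone, whether a piperidin-4-yl ring or a methoxymethyl chain in place of methyl would fall nearer compound 1 or nearer compound 4 stays open. Also open, going by these compounds, is whether oxan-4-yl gives a similar step on a core carrying a different group in place of the ethyl urea.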